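The compounds below may be only part of what the source reports. "The series", "measured", "known", "first", "only" and "open" are said of these compounds alone.

Measured in a functional assay on SNB-19 cells (Homo sapiens) for inhibition, read by MTT assay, with a stated time of 7 days; a higher number here means a weaker inhibitor of growth, a lower number a stronger inhibitor of growth:
- compound 1 `NC(=O)c1ncn2c(=O)n(Cc3ccsc3)nnc12`: > 50000 nM, a limit
- compound 2 `Cc1noc(Cn2nnc3c(C(N)=O)ncn3c2=O)n1`: > 50000 nM, a limit

Compound 2 stands at > 50000 nM, which is a limit and not a number. Compound 3 `NC(=O)c1ncn2c(=O)n(Cc3c[nH]nn3)nnc12` differs from it by 1H-1,2,3-triazol-4-yl in place of 3-methyl-1,2,4-oxadiazol-5-yl on a saturated chain carbon bound to an aromatic nitrogen: 1H-1,2,3-triazol-4-yl in place of 3-methyl-1,2,4-oxadiazol-5-yl, on a saturated chain carbon bound to an aromatic nitrogen. For the measured compounds named here, the only measured step at this place, a step that the two limits leave unreadable from compound 1 to compound 2, gives no size to carry over. No change beyond the scatter is therefore expected in this assay, and no direction can be given. The expected step is a number no higher from compound 2 to compound 3 (the limit leaves the size open). For compound 3 the estimate is 50000 nM, with an expected range from 20000 nM to 100000 nM.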

Compound 3, concentration for 50% growth inhibition: > 50000 nM
Compound 3 was reported as a limit; the forecaster's own chance of this, stated with the estimate: 75%; the middle value sits exactly at the limit.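

No new step can be read from compound 3, whose comparisons with compound 1 and compound 2 run only between limits. The compounds shown leave open whether the group on the saturated chain carbon changes anything in this assay: the limit of > 50000 nM in this assay, at which 3 of the 3 values shown sit.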